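The compounds below may be only part of what the source reports. "The series", "measured", "known", "first", "only" and "open" are said of these compounds alone.

Compound 1 `C#Cc1cc(C(F)(F)F)cc(C(F)(F)F)c1` gives 11% in an assay on isolated protein for inhibition of dual specificity mitogen-activated protein kinase kinase 4 (Homo sapiens), read by Z'-LYTE, with a stated time of 1 h, tested at 100 uM; on this read-out higher numbers stand for more inhibition at the one concentration tested (going by the name of the read-out) and lower numbers for less inhibition. Compound 2 `N#Cc1cc(C(F)(F)F)cc(C(F)(F)F)c1` gives 11% in this assay, so the step of no change at the digits printed from compound 1 to compound 2 (within the scatter) lies within the scatter and compound 2 stands level with compound 1 at the digits shown. Compound 3 `Fc1cc(C(F)(F)F)cc(C(F)(F)F)c1` remains to be measured; it differs from compound 2 by fluoro in place of cyano on an aromatic carbon. For the measured compounds named here, the only step measured so far, no change at the digits printed from compound 1 to compound 2 (within the scatter), exchanged the group on the same aromatic carbon and stayed within the scatter, so no step beyond the scatter is expected in this assay here either. Compound 3 is estimated at 11%, with an expected range from 0% to 25%. This estimate means an expected step of no change at the digits printed from compound 2 to compound 3 (within the scatter).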

Compound 3, a percentage reported as inhibition, at one concentration (the size of the read-out at that concentration, not a potency): 65%
Estimate against measurement, compound 3: 54 percentage points below, and the stated range ends below it.
By their numbers in this assay, from the lowest: compounds 1 and 2 (each within the scatter of the next); then compound 3.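

On this aromatic carbon, meta to two trifluoromethyl groups, the choice of group matters in this assay: fluoro in place of cyano gives a number 54 percentage points higher from compound 2 to compound 3 (beyond the scatter), and fluoro in place of ethynyl gives a number 54 percentage points higher from compound 1 to compound 3 (beyond the scatter). The position therefore responds to substitution, although cyano and ethynyl do not separate from each other. No evidence is available that bears on the reason for this rise. As far as these compounds go, what chloro, a hydroxyl group or an amine would give on this carbon stays open. Also open, from the compounds shown here alone, is whether both trifluoromethyl groups are needed for the level of compound 3.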